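Chain-extended triazole series: cytotoxicity notes

The source may hold more compounds than are shown below. What is called first, only, known or untested is meant among the compounds shown, and "the series" means these compounds.

Measured compounds:
compound 1 `CC[C@@H](CCn1cncn1)c1ccc(C)cc1` gives 69.9 ug/mL in an ADME assay on HEp-2 cells (Homo sapiens) for cytotoxicity, read by MTT assay, with a stated time of 3 days; on this read-out higher numbers stand for lower toxicity in this test and lower numbers for higher toxicity in this test
compound 2 `CCC[C@H](CCn1cncn1)c1ccccc1` gives 58.4 ug/mL in this assay
compound 3 `CCC[C@@H](CCn1cncn1)c1ccc(C)cc1` gives 71.3 ug/mL in this assay

Compound 1 and compound 3 differ by methyl in place of hydrogen on a saturated chain carbon, three bonds along the chain from an aromatic carbon; that change gives a 1.0-fold higher number from compound 1 to compound 3 (0.01 log units; within the scatter). Compound 2 shares no single counted difference with compound 1: the difference between the two cores is not broken down here, and the values of compound 1 and compound 2 lie within the scatter of one another.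

Compound 4 `CCCC[C@H](CCn1cncn1)c1ccccc1` is not yet measured in this assay. It differs from compound 2 by methyl in place of hydrogen on a saturated chain carbon, four bonds along the chain from an aromatic carbon. This is the same kind of change as between compound 1 and compound 3, but the place differs: three bonds along the chain from an aromatic carbon there, four bonds along the chain from an aromatic carbon here.

Because the earlier step of a 1.0-fold higher number from compound 1 to compound 3 (0.01 log units; within the scatter) stayed within the scatter, the step from compound 2 to compound 4 in this assay is expected to be a 1.0-fold higher number from compound 2 to compound 4 (0.01 log units; within the scatter). Compound 4 is estimated at 60 ug/mL, expected between 35 ug/mL and 100 ug/mL.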

Compound 4, half-maximal cytotoxic concentration: 50.2 ug/mL
Compound 4: the middle estimate sits 1.2-fold (0.08 log units) above what was measured; the measured number falls inside the stated range.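

The new step in this assay is a 1.2-fold lower number from compound 2 to compound 4 (0.07 log units; within the scatter) and matches the earlier step on the other core: the same change on two cores in this assay, a 1.0-fold higher number (0.01 log units; within the scatter) from compound 1 to compound 3 and a 1.2-fold lower number (0.07 log units; within the scatter) from compound 2 to compound 4, 1.2-fold (0.07 log units) apart, within the scatter of two such steps

Methyl in place of hydrogen therefore leaves the number within the scatter on both cores, and the two steps cannot be told apart. For the compounds shown here, this rests on only two pairs, with the change three bonds along the chain from an aromatic carbon in one and four bonds along in the other, so it shows neither a trend with chain length nor that the change would carry to any further core.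

The compounds shown leave open whether a longer chain than butyl would also stay within the scatter. They also leave open how an amine or a carboxylic acid in place of the methyl would read.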